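This account rests on a few compounds, and the source may have more. Where it says the series, first, only, none or still open, it means among the compounds named here.

The measured compounds are these three. Compound 1 `C#CCNC(=O)/C=C/c1cnc(Nc2ccc(C#N)cc2)nc1Oc1c(C)cc(C#N)cc1C` gives in an ADME assay on TZM cells (Homo sapiens) for cytotoxicity, with a stated time of 1 days (on this read-out lower numbers stand for higher toxicity in this test and higher numbers for lower toxicity in this test), a reading that is only a limit, > 222 nM. Compound 2 `Cc1cc(C#N)cc(C)c1Oc1nc(Nc2ccc(C#N)cc2)ncc1/C=C/C(=O)NCC1CCN(S(C)(=O)=O)CC1` gives in this assay likewise only a limit, > 171 nM. Compound 3 `Cc1cc(C#N)cc(C)c1Oc1nc(Nc2ccc(C#N)cc2)ncc1/C=C/C(=O)NCC1CCN(S(C)(=O)=O)C1` gives in this assay again only a limit, > 175 nM.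

For the measured compounds named here, compound 3 therefore stands nowhere in particular on these numbers: its reading is a limit, and the two other readings are limits as well, so no compound can be placed above or below another. The steps between them, a step that the two limits leave unreadable from compound 1 to compound 3 and a step that the two limits leave unreadable from compound 2 to compound 3 and also a step that the two limits leave unreadable from compound 1 to compound 2, are all unreadable for the same reason, as the limit of > 171 nM in this assay, at which 1 of the 3 values shown sits, the limit of > 175 nM in this assay, at which 1 of the 3 values shown sits, and the limit of > 222 nM in this assay, at which 1 of the 3 values shown sits, show.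

Compound 4 `CC(=O)N1CCN(C(=O)/C=C/c2cnc(Nc3ccc(C#N)cc3)nc2Oc2c(C)cc(C#N)cc2C)CC1` differs from compound 3 by 4-acetylpiperazin-1-yl in place of ((1-(methylsulfonyl)pyrrolidin-3-yl)methyl)amino on a carbonyl carbon. The measured steps that touch the same part of the molecule, the amide side of the chain, are all unreadable, so they give no size and no direction to carry over. Compound 4 is accordingly expected to give in this assay a reading near the limits of the others, 250 nM, with a range from 100 nM to 1000 nM, an expected step that the limit leaves unreadable from compound 3 to compound 4.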

Compound 4, half-maximal cytotoxic concentration: > 192 nM
Compound 4: no number, only a limit (the forecaster's own chance of this, stated with the estimate: 80%); the middle value does not contradict the limit.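

In this assay compound 4 gives only a limit, > 192 nM, so its steps from compound 1, compound 2 and compound 3 cannot be read. The compounds shown leave open where any of the four actually lies and whether changing the amide side alters the reading at all.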